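Compound 4: Amino for Chloro on the Shared Core

This account rests on a few compounds, and the source may have more. Where it says the series, first, only, none or still open, it means among the compounds named here.

Compound 3 `CC(O)n1cnc2c(Cl)nc(I)nc21` sits at the assay limit in a functional assay on HT-29 cells (Homo sapiens) for inhibition; on this read-out higher numbers stand for weaker inhibition and lower numbers for stronger inhibition: compound 3 gives > 500000 nM, which is a limit rather than a number. The same limit holds for compound 1 `CC(=O)OC(C)n1cnc2c(Cl)nc(N)nc21`, which gives > 500000 nM in this assay, as recorded in the limit of > 500000 nM in this assay, at which 2 of the 3 values shown sit. Only compound 2 `CC(=O)OC(C)n1cnc2c(Cl)nc(I)nc21` yields a number, giving 6420 nM in this assay. Two steps are measured: an at least 77-fold lower number from compound 1 to compound 2 (1.89 log units; beyond the scatter) and an at least 77-fold higher number from compound 2 to compound 3 (1.89 log units; beyond the scatter), both large. Within the data shown here, compound 4 `CC(O)n1cnc2c(N)nc(I)nc21` differs from compound 3 by amino in place of chloro on an aromatic carbon, a change at a place that neither measured step touches, so no measured step bears on it directly. With compound 3 at the limit, compound 4 is expected to remain at the limit too, with an estimated 500000 nM (range 50000 nM to 5000000 nM), an expected step of a number no higher from compound 3 to compound 4 (the limit leaves the size open).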

Compound 4, half-maximal inhibitory concentration: > 500000 nM
Compound 4: only a limit was reported; the forecaster's own chance of this, stated with the estimate: 80%; the middle value lies on the limit itself.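

Compound 3 and compound 4 both sit at a limit in this assay, so the step between them cannot be read: the limit of > 500000 nM in this assay, at which 3 of the 4 values shown sit.

The compounds shown leave open how amino and chloro compare at this place on the shared core.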